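This account rests on a few compounds, and the source may have more. Where it says the series, first, only, none or still open, it means among the compounds named here.

Measured compounds:
compound 1 `O=C1c2ccccc2S(=O)(=O)N1CCCCCCN1CCN(c2ccccc2Cl)CC1` gives 459 nM in an ADME assay on HEK293 cells for displacement of a labelled ligand from 5-hydroxytryptamine receptor 6 (Homo sapiens), read by radioligand binding, with a stated time of 1 h; on this read-out higher numbers stand for weaker inhibition and lower numbers for stronger inhibition
compound 2 `O=C1c2ccccc2S(=O)(=O)N1CCCCCCN1CCN(c2ccc(Cl)c(Cl)c2)CC1` gives 132 nM in this assay
compound 3 `O=C1c2ccccc2S(=O)(=O)N1CCCCCCN1CCN(c2ccccc2)CC1` gives 971 nM in this assay

Compound 3, with the bare phenyl on the ring amine nitrogen, stands highest of the three numbers. The nearest of the others is reached by a 2.1-fold higher number from compound 1 to compound 3 (0.33 log units; beyond the scatter), the furthest by a 7.4-fold higher number from compound 2 to compound 3 (0.87 log units; beyond the scatter). Both changes to that phenyl, the single chloro and the 3,4-dichloro pattern, therefore give lower numbers than the bare ring, and a 3.5-fold lower number from compound 1 to compound 2 (0.54 log units; beyond the scatter) shows the dichloro ring lower still.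

Compound 4 `O=C1c2ccccc2S(=O)(=O)N1CCCCCCN1CCN(c2cccc3ccccc23)CC1` is the next step from compound 3: naphthalen-1-yl in place of phenyl on an amine nitrogen in a ring. Going by the values given here, no measured step replaces the phenyl with a fused second aromatic ring, so the bearing of the three steps is indirect; they show only that every departure from the bare phenyl so far has lowered the number in this assay, by modest amounts. On that basis compound 4 is expected to move by about a 2.8-fold lower number from compound 3 to compound 4 (0.44 log units; beyond the scatter), a modest lower number rather than none. The estimate for compound 4 is 350 nM, with a range from 100 nM to 1200 nM.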

Compound 4, inhibition constant: 157 nM
For compound 4 the middle estimate is 2.2-fold (0.35 log units) above the measured one; the measured number falls inside the stated range.
By their numbers in this assay, from the lowest: compounds 2 and 4 (each within the scatter of the next); then compound 1; then compound 3.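

On the amine nitrogen in the six-membered ring, a second fused aromatic ring of carbon alone, with no chloro, is enough to move the number: naphthalen-1-yl in place of phenyl gives a 6.2-fold lower number from compound 3 to compound 4 (0.79 log units; beyond the scatter) in this assay. The same group also differs clearly from the single chloro ring, with a 2.9-fold lower number from compound 1 to compound 4 (0.47 log units; beyond the scatter), while a 1.2-fold higher number from compound 2 to compound 4 (0.08 log units; within the scatter) leaves it within the scatter of the 3,4-dichlorophenyl ring, so two quite different groups at this position read alike. Nothing at hand accounts for these steps.

The compounds shown leave open how naphthalen-2-yl, a quinolinyl ring or a methoxy group on the phenyl would read at this position. They also leave open whether compound 2 and compound 4 would still read alike with a shorter chain on the other ring nitrogen.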